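Hydroxy for Bromo in a Weakly Cytotoxic Series

A few compounds are considered here, and "the series" means these few. Any claim that something is new, unique, unknown or untested is made for them only; others in the source may bear on it.

Measured compounds:
compound 1, `O=C(CSC(=S)N[C@H]1CCOC1=O)Nc1ccc(Br)cc1` — 67400 nM
compound 2, `O=C(CSC(=S)N[C@H]1CCOC1=O)Nc1ccc(Cl)cc1Cl` — limit > 128000 nM

Going by the values given here, in a functional assay on EC9706 cells (Homo sapiens) for cytotoxicity, read by MTT assay, with a stated time of 72 h (on this read-out higher numbers stand for weaker inhibition and lower numbers for stronger inhibition), compound 1 gives 67400 nM, the only plain number in this set. Compound 2 reaches only the limit > 128000 nM in this assay, a cut-off of the measurement rather than a number. the limit of > 128000 nM in this assay, at which 1 of the 2 values shown sits, describes that cut-off. Compound 1 therefore stands alone as a measured value, and it is a weak inhibitor.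

Compound 3, `O=C(CSC(=S)N[C@H]1CCOC1=O)Nc1ccc(O)cc1`, has not yet been measured. It differs from compound 1 in one place:
hydroxy in place of bromo on an aromatic carbon

Among the compounds with values here, no step between measured compounds exists to calibrate this change, so the expectation rests on compound 1 alone. In this assay the shift is expected to be a 1.4-fold higher number from compound 1 to compound 3 (0.15 log units; within the scatter), a small move toward weaker inhibition that may well stay within the scatter. Compound 3 is thus expected to give 95000 nM, with a likely range from 35000 nM to 260000 nM.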

Compound 3, half-maximal inhibitory concentration: > 128000 nM
Compound 3 gave a limit, no number; the forecaster's own chance of this, stated with the estimate: 40%; at least 1.3-fold (0.12 log units) between middle value and limit.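

In this assay, going by these compounds alone, putting hydroxy in place of bromo on the aromatic carbon gives an at least 1.8-fold higher number from compound 1 to compound 3 (0.27 log units; that floor lies within the scatter), the first look at how this position responds to a change. Since that floor lies within the scatter, the step shows no clear loss, but it does show that this hydroxy brings no measurable gain in inhibition over the bromo group of compound 1. Within the data shown here, compound 3 gives a limit of the assay rather than a number, leaving compound 1 as the only plain value in the set: the limit of > 128000 nM in this assay, at which 2 of the 3 values shown sit.

From the compounds shown here alone, how far the true value of compound 3 lies past that limit stays unknown, so the change could be small or large. Going by these compounds, whether an amine, a methoxy group or a carboxylic acid at this place would give stronger inhibition than bromo also remains open.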